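Nitro placement on the hydrazide series: compound 4 ahead of measurement

A few compounds are considered here, and "the series" means these few. Any claim that something is new, unique, unknown or untested is made for them only; others in the source may bear on it.

Measured so far in an ADME assay on A549 cells (Homo sapiens) for cytotoxicity, read by MTT assay, with a stated time of 72 h; a lower number here means a stronger inhibitor, a higher number a weaker inhibitor:
compound 1, `O=C(NNC(=O)c1ccc(-n2cccc2)cc1)c1ccccc1`, 215000 nM
compound 2, `O=C(NNC(=O)c1ccccc1[N+](=O)[O-])c1ccc(-n2cccc2)cc1`, 205000 nM
compound 3, `O=C(NNC(=O)c1ccccc1Br)c1ccc(-n2cccc2)cc1`, 201000 nM

Compound 1 gives the highest of the three numbers, but its neighbours sit close: a 1.0-fold lower number from compound 1 to compound 2 (0.02 log units; within the scatter) and a 1.1-fold lower number from compound 1 to compound 3 (0.03 log units; within the scatter), both within the scatter, and likewise a 1.0-fold lower number from compound 2 to compound 3 (0.01 log units; within the scatter). Among the measured compounds shown here, no compound among the three can be called stronger or weaker than another on these numbers.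

Compound 4, `O=C(NNC(=O)c1cccc([N+](=O)[O-])c1)c1ccc(-n2cccc2)cc1`, is the next member, not yet measured in this assay . It differs from compound 1 by nitro in place of hydrogen on an aromatic carbon. The step from compound 1 to compound 2 is the one that bears on it most directly, since it also puts nitro in place of hydrogen on an aromatic carbon of the shared core, though not at the same place; that step stayed within the scatter. The bromo step from compound 1 to compound 3 was equally flat. The expectation is therefore a step of no size beyond the scatter: for compound 4 the estimate is 210000 nM, range 140000 nM to 310000 nM, which means the expected step of a 1.0-fold lower number from compound 1 to compound 4 (0.01 log units; within the scatter).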

Compound 4, half-maximal inhibitory concentration: 203000 nM
Compound 4: middle estimate off by 1.0-fold (0.01 log units), on the high side; the range from low to high includes it.
By their numbers in this assay, from the lowest: compounds 3, 4, 2 and 1 (each within the scatter of the next).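

In (this assay), nitro meta to a large group on the six-membered aromatic ring gives a step within the scatter (a 1.1-fold lower number from compound 1 to compound 4 (0.02 log units; within the scatter)). Among the compounds shown here, this adds a second nitro placement to the one in compound 2, and the two placements cannot be told apart on these numbers, with compound 2 at (205000 nM) and compound 4 at (203000 nM). No measurement is available that would account for this flat result.

From the compounds shown here alone, whether an amine or a carboxylic acid at this place would give a step beyond the scatter remains open. Going by these compounds, all four compounds also keep the rest of the shared core unchanged, so the effect of changes elsewhere on it remains unknown.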